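A few compounds are considered here, and "the series" means these few. Any claim that something is new, unique, unknown or untested is made for them only; others in the source may bear on it.

Measured compounds:
- Compound 1, `CCCn1nnc2c(Br)cccc21`: 4.7 mL/min/g
- Compound 2, `Clc1cccc2c1nnn2CC1CC1`: 4.2 mL/min/g

Two compounds sharing a fused bicyclic core were examined in an ADME assay on microsomes from liver (Homo sapiens) for metabolic stability, tested at 2.5 uM; on this read-out lower numbers stand for slow clearance and higher numbers for fast clearance. Compound 1 gives 4.7 mL/min/g in this assay, and compound 2 gives 4.2 mL/min/g. Compound 2 holds the lowest of the two numbers, but compound 1 sits so close that the gap between them lies within the scatter of repeated measurements, so the two values cannot be told apart.

The next compound, compound 3, `FC(F)(F)c1cccc2c1nnn2CC1CC1`, is not yet measured. It differs from compound 2 in one place: trifluoromethyl in place of chloro on an aromatic carbon. For the measured compounds named here, no measured pair shows what this kind of change does in this assay, so there is no step to lean on. Since both measured numbers sit close together, compound 3 is expected to stay in the same region, with a step of a 1.1-fold lower number from compound 2 to compound 3 (0.04 log units; within the scatter) that does not go beyond the scatter. Compound 3 is estimated at 3.8 mL/min/g, in the range 2 mL/min/g to 7.5 mL/min/g.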

Compound 3, intrinsic clearance in a liver preparation (reported as CLH), per the amount of preparation that the assay uses: 0.3 mL/min/g
Beside the measured number, compound 3's estimate is 13-fold (1.10 log units) above it, and the stated range ends above it.
By their numbers in this assay, from the lowest: compound 3; then compounds 2 and 1 (each within the scatter of the next).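

In this assay, trifluoromethyl in place of chloro on an aromatic carbon of the six-membered aromatic ring gives a 14-fold lower number from compound 2 to compound 3 (1.15 log units; beyond the scatter), the only step shown so far and one that lies beyond the scatter. This shows that a change at this single position, with the rest of the structure kept, can move the read-out far, something compounds 1 and 2 could not show, as their values lie within the scatter of each other and they differ in more than one place. Nothing shown here accounts for the size of this step.

From the compounds shown here alone, it remains open whether a nitrile, a methoxy group or an amine at this aromatic carbon would give a similar step. Going by these compounds, it is also open whether trifluoromethyl would have the same effect with a longer chain on the shared core.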